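This account rests on a few compounds, and the source may have more. Where it says the series, first, only, none or still open, it means among the compounds named here.

Compound 1 `CS(=O)(=O)c1ccc(C(=O)Nc2ccc(Cl)c(-c3nnc4c(Cl)cccn34)c2)c(Cl)c1` is an amide bearing a methylsulfonyl group. In a functional assay on T47D cells (Homo sapiens) for antiproliferative activity, read by MTT assay, with a stated time of 72 h (a higher number here means a weaker inhibitor, a lower number a stronger inhibitor), compound 1 gives only a limit of the assay, > 100000 nM. Compound 2 `Cc1nc(C(=O)Nc2ccc(Cl)c(-c3nnc4c(Cl)cccn34)c2)cs1` in this assay also gives only a limit, > 100000 nM. Compound 3 `Cc1cc(Cl)ccc1C(=O)Nc1ccc(Cl)c(-c2nnc3c(Cl)cccn23)c1` in this assay likewise gives only a limit, > 100000 nM. The step that the two limits leave unreadable from compound 2 to compound 3 therefore cannot be read. Compound 4 `O=C(Nc1ccc(Cl)c(-c2nnc3c(Cl)cccn23)c1)c1ccc(Cl)cc1Cl` differs from compound 1 by chloro in place of methylsulfonyl on an aromatic carbon. Among the compounds with values here, no measured step bears directly on this change, since all three values shown sit at the limit (the limit of > 100000 nM in this assay, at which 3 of the 3 values shown sit). Compound 4 is therefore expected to remain at that same limit, so the expected step that the limit leaves unreadable from compound 1 to compound 4 cannot be read beyond the scatter. The estimate for compound 4 is 150000 nM, with a range from 40000 nM to 600000 nM.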

Compound 4, half-maximal inhibitory concentration: > 100000 nM
Compound 4: a limit, no number; the forecaster's own chance of this, stated with the estimate: 85%; the middle value is on the limit's open side.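

Compound 4 in this assay gives only a limit, > 100000 nM, so its steps from compound 1, compound 2 and compound 3 cannot be read. The compounds shown leave open whether any change to the group on the amide carbonyl would give a measurable value: the limit of > 100000 nM in this assay, at which 4 of the 4 values shown sit.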